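The source may report more compounds than this note shows. Statements on the series, on what has been measured and on what is new or still open speak of the compounds shown alone.

Measured compounds:
Compound 1, `Cc1nc(-c2ccc(C(F)(F)F)cc2)sc1CNc1ccc(/C=C/C(=O)O)cc1`, gives 95%.
Compound 2, `CC(C)(Oc1ccc(NCc2cccc(Oc3ccccc3)c2)cc1)C(=O)O`, gives 14%.

Both values come from a functional assay on CHO cells for agonist activity at Free fatty acid receptor 1 (Homo sapiens), read by a luciferase reporter; a lower number here means a smaller maximal response, a higher number a larger maximal response. Compound 1 stands highest of the two numbers; its nearest neighbour, compound 2, lies far lower, a gap beyond the usual scatter. Within the data shown here, compound 2 does not differ from compound 1 in a single place, so the two readings show only that one compound reaches nearly the full response and the other a small one, with no step to be drawn between them.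

Compound 3, `Cc1nc(-c2ccc(C(F)(F)F)cc2)sc1CNc1ccc([C@H]2C[C@@H]2C(N)=O)cc1`, has not yet been measured in this assay. It differs from compound 1 in one place: 2-carbamoylcyclopropyl in place of 2-carboxyethenyl on an aromatic carbon. In words of the change, 2-carbamoylcyclopropyl stands in place of 2-carboxyethenyl on an aromatic carbon, para to a large group.

Among the measured compounds shown here, no pair of measured compounds differing in one place is available to guide this step. Compound 1 with the 2-carboxyethenyl group reaches nearly the full maximal response. Compound 3 is expected to fall in this assay, a downward step of a number 40 percentage points lower from compound 1 to compound 3 (beyond the scatter) that goes beyond the scatter. Compound 3 is therefore estimated to reach 55% in this assay, within a range from 20% to 95%.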

Compound 3, largest response reached (reported as percent of maximum), in percent of the reference or control that the assay uses: 80%
Beside the measured number, compound 3's estimate is 25 percentage points below it, and the stated range covers the measured number.
By their numbers in this assay, from the lowest: compound 2; then compound 3; then compound 1.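

In this assay, placing 2-carbamoylcyclopropyl instead of 2-carboxyethenyl on this aromatic carbon, para to a large group, leaves the response a number 15 percentage points lower from compound 1 to compound 3 (beyond the scatter), a modest step, and compound 3 still reaches 80%. At this position on the core of compound 1, a carboxy group is therefore not required for a large maximal response, and a carbamoyl group carried on a three-membered carbon ring can serve in its place, although the response does not fully match that of compound 1. Nothing measured here explains this step, so the reason for the modest drop remains unknown.

The change replaces the ethenyl link and the carboxy group at once, so the compounds shown cannot assign the step to either part; a cyclopropyl group bearing a carboxylic acid, or an ethenyl group bearing a carboxamide, would separate the two. They also leave open how the response depends on the two defined stereocentres of compound 3, since its mirror-image form and the other cyclopropane arrangements do not appear among them.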